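A few compounds are considered here, and "the series" means these few. Any claim that something is new, unique, unknown or untested is made for them only; others in the source may bear on it.

Working notes on the series.

Compound 1, `CN1CCCC1COc1cnc(Cl)c(/C=C/c2ccncc2)c1`, in an assay for binding affinity to Neuronal acetylcholine receptor; alpha4/beta2 (Rattus norvegicus) (a lower number here means a stronger inhibitor, a higher number a weaker inhibitor), gives 0.028 nM. For the measured compounds named here, compound 2, `Clc1ncc(OCC2CCCN2)cc1/C=C/c1ccccn1`, in this assay gives 0.331 nM, which is the higher of the two numbers measured so far; the difference from compound 1 is beyond the scatter. The two structures differ in more than one place, so the two values are shown side by side only and no single change is assigned to the gap between them.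

Compound 3, `CN1CCCC1COc1cnc(Cl)c(/C=C/c2ccccn2)c1`, has not been measured in this assay. Relative to compound 2 the change is methyl in place of hydrogen on an amine nitrogen in a ring. Compound 3 thereby carries the same ring substituent on the amine nitrogen as compound 1, while keeping the rest of compound 2 unchanged. Going by the values given here, no measured pair isolates this change, so its size is open. Because compound 1 gives 0.028 nM, the expectation is that adding the methyl moves the number downward, with a step estimated at a 3.3-fold lower number from compound 2 to compound 3 (0.52 log units; beyond the scatter), though part of the gap between compound 1 and compound 2 may belong to the other difference. For compound 3 the estimate in this assay is 0.1 nM, with a range from 0.02 nM to 0.5 nM.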

Compound 3, inhibition constant: 0.265 nM
Beside the measured number, compound 3's estimate is 2.7-fold (0.42 log units) below it; measured number inside the range.
By their numbers in this assay, from the lowest: compound 1; then compounds 3 and 2 (each within the scatter of the next).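

In this assay, methyl in place of hydrogen on the amine nitrogen in the ring, the change from pyrrolidin-2-yl to 1-methylpyrrolidin-2-yl, gives a 1.2-fold lower number from compound 2 to compound 3 (0.10 log units; within the scatter) and so does not separate the two compounds when pyridin-2-yl is on the chain. The single-change comparison at the other place gives a 9.5-fold higher number from compound 1 to compound 3 (0.98 log units; beyond the scatter) for pyridin-2-yl in place of pyridin-4-yl on the double-bonded chain carbon, which makes this the only step shown that lies beyond the scatter. No measurement shown here offers a reason for either step.

Going by these compounds, the amine nitrogen reading rests on one pair with pyridin-2-yl, so it remains open whether hydrogen in place of methyl gives a similarly small step when pyridin-4-yl is on the chain, or whether an ethyl or a longer chain on that nitrogen departs from this reading. For the compounds shown here, the chain end is also defined by only two groups, leaving open where pyridin-3-yl or a plain phenyl would fall relative to pyridin-2-yl and pyridin-4-yl.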